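The source may report more compounds than this note shows. Statements on the series, on what has been measured and on what is new or still open speak of the compounds shown alone.

Measured compounds in a functional assay on MCF7 cells (Homo sapiens) for antiproliferative activity, read by MTT assay, with a stated time of 72 h; on this read-out higher numbers stand for weaker inhibition and lower numbers for stronger inhibition:
compound 1, `O=C(Nc1ccc(Cl)c(-c2nnc3c(Cl)cccn23)c1)c1cccc(Cl)c1`, gives 71900 nM.
compound 2, `O=C(Nc1ccc(Cl)c(-c2nnc3c(Cl)cccn23)c1)c1ccccc1`, gives > 100000 nM.

Compound 2 stands at a limit: the value recorded for compound 2 in this assay, > 100000 nM, is a limit of the assay and not a number. That limit, (the limit of > 100000 nM in this assay, at which 1 of the 2 values shown sits), is where one of the two measured values sits. For the measured compounds named here, compound 1 gives 71900 nM in this assay, and the only measured step between the two, an at least 1.3-fold higher number from compound 1 to compound 2 (0.14 log units; that floor lies within the scatter), goes with hydrogen in place of chloro on an aromatic carbon.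

Compound 3, `CS(=O)(=O)c1cccc(C(=O)Nc2ccc(Cl)c(-c3nnc4c(Cl)cccn34)c2)c1`, differs from compound 2 by methylsulfonyl in place of hydrogen on an aromatic carbon. Going by the values given here, no measured step concerns a methylsulfonyl group, so the single step available, an at least 1.3-fold higher number from compound 1 to compound 2 (0.14 log units; that floor lies within the scatter), bears on it only in showing that a small change on that ring moved the number little and toward the limit. The expected step from compound 2 to compound 3 in this assay is therefore a number no higher from compound 2 to compound 3 (the limit leaves the size open), none beyond the scatter. Compound 3 is estimated at 100000 nM in this assay, with a range from 35000 nM to 300000 nM.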

Compound 3, half-maximal inhibitory concentration: 88900 nM
Compound 3: middle estimate off by 1.1-fold (0.05 log units), on the high side; low and high end bracket the measured number.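

The position meta to a large group on the six-membered aromatic ring of carbon only now carries two different groups with measured numbers in this assay, and chloro and methylsulfonyl cannot be told apart there: a 1.2-fold higher number from compound 1 to compound 3 (0.09 log units; within the scatter). The comparison with hydrogen at this position gives only a floor and no size for the change, and that floor stays inside the scatter: an at least 1.1-fold lower number from compound 2 to compound 3 (0.05 log units; that floor lies within the scatter). The value of compound 2 is a limit of the assay and not a number, so the true distance from compound 2 to compound 3 remains unknown: the limit of > 100000 nM in this assay, at which 1 of the 3 values shown sits.

From the compounds shown here alone, what an amine, a carboxylic acid or a longer chain at this position would give remains open, as does whether any group there can reach a number beyond the scatter from compound 1 and compound 3. Also open is how chloro or methylsulfonyl would read on another carbon of this ring, since all the compounds shown keep the rest of the shared core unchanged and vary only this one place.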